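This account rests on a few compounds, and the source may have more. Where it says the series, first, only, none or still open, it means among the compounds named here.

Compound 1 `COc1cc(-c2cc3c(O)nc(C)nc3cc2C(C)C)ccc1Cl` gives 14 nM in a functional assay for inhibition of transient receptor potential cation channel subfamily V member 1 (Homo sapiens), read by fluorescence and calcium flux; a lower number here means a stronger inhibitor, a higher number a weaker inhibitor.
Compound 2 `Cc1nc(O)c2cc(-c3ccc(Cl)c(OCC(=O)O)c3)c(C(C)C)cc2n1` gives only a limit, > 1000 nM.
Compound 3 `CCCCOc1cc(-c2cc3c(O)nc(C)nc3cc2C(C)C)ccc1Cl` gives 82 nM.

Among the two plain numbers in this assay, compound 3 stands highest. Compound 4 `Cc1nc(O)c2cc(-c3ccc(Cl)c(OCCO)c3)c(C(C)C)cc2n1` differs from compound 3 by hydroxy in place of ethyl on a saturated chain carbon, two bonds along the chain from an oxygen on an aromatic ring. For the measured compounds named here, two measured steps bear on this change. Lengthening the chain from hydrogen gave a 5.9-fold higher number from compound 1 to compound 3 (0.77 log units; beyond the scatter), whereas adding a carboxy gave an at least 71-fold higher number from compound 1 to compound 2 (1.85 log units; beyond the scatter), reaching the limit (the limit of > 1000 nM in this assay, at which 1 of the 3 values shown sits). Compound 4 has a shorter chain than compound 3 but gains a hydroxy, so the two steps from compound 1 point in opposite directions, one modest and one large. The step expected from compound 3 to compound 4 is a 1.6-fold lower number from compound 3 to compound 4 (0.21 log units; within the scatter). Compound 4 is therefore estimated at 50 nM, with a range from 12 nM to 300 nM.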

Compound 4, half-maximal inhibitory concentration: 557 nM
The estimate for compound 4 lay 11-fold (1.05 log units) below the measured number; measured number above the stated range.
By their numbers in this assay, from the lowest: compound 1; then compound 3; then compound 4. At a limit, above all of these: compound 2.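

Length alone does not set the number at this place in this assay: 2-hydroxyethoxy is shorter than butoxy, yet the change gives a 6.8-fold higher number from compound 3 to compound 4 (0.83 log units; beyond the scatter) and the smallest chain compares worse still, with a 40-fold higher number from compound 1 to compound 4 (1.60 log units; beyond the scatter) as its step. For the compounds shown here, the hydroxy and carboxy compounds cannot be firmly ranked, with an at least 1.7-fold lower number from compound 2 to compound 4 (0.25 log units; that floor lies within the scatter) as the only reading. Compound 2 stands at a limit, not a number: the limit of > 1000 nM in this assay, at which 1 of the 4 values shown sits.

Open, on these data alone, is whether a chain-end hydroxy always costs this much, or whether an amine or a longer chain ending in hydroxy would fare differently.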